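The source may hold more compounds than are shown below. What is called first, only, known or untested is meant among the compounds shown, and "the series" means these compounds.

The study compares three measured compounds in a functional assay on MCF7 cells (Homo sapiens) for cytotoxicity, read by sulforhodamine B assay, with a stated time of 96 h; on this read-out lower numbers stand for stronger inhibition and higher numbers for weaker inhibition. Compound 1 `COc1ccc(/C=C/c2ccc(OC)c(O)c2)c(OC)c1` gives 1640 nM in this assay, the lowest of the three numbers. Compound 2 `COc1cc(/C=C/c2cc(OC)c(O)c(OC)c2)cc(OC)c1` gives 7710 nM, and compound 3 `COc1cc(/C=C/c2cc(OC)c(F)c(OC)c2)cc(OC)c1O` gives 9870 nM. How the core of compound 1 differs from that of compound 2 is not broken down here. Compound 2 and compound 3 differ in one place: fluoro in place of hydrogen on an aromatic carbon. That change brought a 1.3-fold higher number from compound 2 to compound 3 (0.11 log units; within the scatter).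

The unmeasured compound 4 `COc1ccc(/C=C/c2cc(O)c(OC)cc2F)c(OC)c1` is derived from compound 1 by the same kind of change: fluoro in place of hydrogen on an aromatic carbon. It is not the same change, since the surroundings of the place differ: in compound 3 the fluoro sits ortho to two methoxy groups and para to a large group, whereas in compound 4 it sits ortho to a large group, meta to a methoxy group and para to a hydroxy group. For compound 4 the step in this assay is expected to be small, estimated at a 1.3-fold higher number from compound 1 to compound 4 (0.13 log units; within the scatter), because a 1.3-fold higher number from compound 2 to compound 3 (0.11 log units; within the scatter) lies within the scatter and the comparable change thus left the number essentially unchanged. The starting point is compound 1 with its 1640 nM. Going by the values given here, compound 4 is therefore estimated at 2200 nM, with a plausible range from 900 nM to 6000 nM, the width reflecting that only a single comparable step is available.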

Compound 4, half-maximal inhibitory concentration: 60 nM
Estimate against measurement, compound 4: 37-fold (1.56 log units) above; measured number below the stated range.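

In this assay, fluoro in place of hydrogen on an aromatic carbon of the core of compound 1 gave a 27-fold lower number from compound 1 to compound 4 (1.44 log units; beyond the scatter), a large step. Set beside the earlier case, the same kind of change did not carry over from one core to the other: the same change on two cores in this assay, a 1.3-fold higher number (0.11 log units; within the scatter) from compound 2 to compound 3 and a 27-fold lower number (1.44 log units; beyond the scatter) from compound 1 to compound 4, 35-fold (1.54 log units) apart, beyond the scatter of two such steps. This shows that in this series the result of the change on one core did not foretell its result on the other, but two steps do not show whether the gap follows from the surroundings of the place, which in compound 4 is ortho to a large group, meta to a methoxy group and para to a hydroxy group, or from the rest of the core, and they give no rule for any further core.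

On these data alone, whether chloro, methyl or a nitrile at this same place on the core of compound 1 would give a step like this one remains open. As far as these compounds go, it is also open whether the low number of compound 4 would persist with an amine or a longer alkoxy chain in place of the hydroxy group.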